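Cytotoxicity notes: chain replacement at the core methylene carbon

A few compounds are considered here, and "the series" means these few. Any claim that something is new, unique, unknown or untested is made for them only; others in the source may bear on it.

compound 1 `NC(=O)CCc1c(Cn2c(=O)n(C3CC3)c3ccncc32)nc2cc(Cl)ccn12`: > 100000 nM (a limit)
compound 2 `CS(=O)(=O)CCc1c(Cn2c(=O)n(C3CC3)c3ccncc32)nc2cc(Cl)ccn12`: > 100000 nM (a limit)

In an ADME assay on HEp-2 cells (Homo sapiens) for cytotoxicity, read by CCK-8 assay, with a stated time of 6 days (a lower number here means that less compound is tolerated, a higher number that more compound is tolerated), compound 1 gives > 100000 nM, which is a limit of the assay and not a number. In this assay compound 2 gives > 100000 nM, again a limit rather than a number. Going by the values given here, the only measured step, a step that the two limits leave unreadable from compound 1 to compound 2, therefore cannot be sized: both ends sit at the same limit. Compound 2 stands at the limit of > 100000 nM in this assay, at which 2 of the 2 values shown sit, so nothing in the measured data places it anywhere other than at that limit.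

Compound 3 `O=c1n(Cc2nc3cc(Cl)ccn3c2CNCCO)c2cnccc2n1C1CC1` differs from compound 2 by (2-hydroxyethyl)amino in place of (methylsulfonyl)methyl on a saturated chain carbon bound to an aromatic carbon. Among the compounds with values here, the one measured step bears on this change only loosely: it also exchanged the terminal group of the same chain, and left the read-out at the limit on both sides, so no direction or size of effect is readable from it. No step beyond the scatter is therefore expected in this assay from this change, in either direction.

Compound 3 is thus estimated at 150000 nM in this assay, with a range from 50000 nM to 500000 nM. The expected step that the limit leaves unreadable from compound 2 to compound 3 is accordingly taken as none beyond the scatter, most likely reported again only as a limit.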

Compound 3, half-maximal cytotoxic concentration: > 100000 nM
Compound 3 ended at the assay's limit; the forecaster's own chance of this, stated with the estimate: 80%; the middle value does not contradict the limit.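

In this assay compound 3 gives > 100000 nM, a limit of the assay and not a number. No step among compound 1, compound 2 and compound 3 can be read, since all three sit at the same limit: the limit of > 100000 nM in this assay, at which 3 of the 3 values shown sit.

The compounds shown leave open at what concentration any of them turns cytotoxic, and whether the chain replacements differ at all.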